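Methoxy removal on the shared core: cytotoxicity notes

The source may report more compounds than this note shows. Statements on the series, on what has been measured and on what is new or still open speak of the compounds shown alone.

Measured compounds in an ADME assay on MT4 cells (Homo sapiens) for cytotoxicity, read by MTT assay, with a stated time of 96 h; a lower number here means that less compound is tolerated, a higher number that more compound is tolerated:
compound 1 `COc1ccc(-c2nc3cc(C(F)(F)F)ccc3[nH]2)c(OC)c1OC`: 93000 nM
compound 2 `COc1ccc(-c2nc3cc(C(F)(F)F)ccc3[nH]2)c(OC)c1`: > 100000 nM
compound 3 `COc1ccc(-c2nc3cc(C(C)=O)ccc3[nH]2)c(OC)c1`: > 100000 nM

Compound 1 gives a readable number in this assay. Compound 2 reaches only > 100000 nM, which is a limit of the assay and not a number. Compound 3 likewise stops at > 100000 nM, again a limit. Two of the three values shown therefore sit at the limit of > 100000 nM in this assay, at which 2 of the 3 values shown sit, so compound 2 stands at the upper edge of what the numbers can show.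

Among the measured compounds shown here, the one step that is readable in part, an at least 1.0-fold higher number from compound 1 to compound 2 (0.03 log units; that floor lies within the scatter), is the same kind of change as the one now considered: hydrogen in place of methoxy on an aromatic carbon, giving compound 4 `COc1ccc(-c2nc3cc(C(F)(F)F)ccc3[nH]2)cc1`. The other step, a step that the two limits leave unreadable from compound 2 to compound 3, adds nothing readable. For the measured compounds named here, the only bearing step is at its floor and within the scatter, so no step beyond the scatter is expected in this assay for compound 4.

Compound 4 is therefore expected to remain at the limit, with an estimate of 130000 nM (range 70000 nM to 300000 nM), which means an expected step that the limit leaves unreadable from compound 2 to compound 4.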

Compound 4, half-maximal cytotoxic concentration: 2000 nM
Estimate against measurement, compound 4: 65-fold (1.81 log units) above, outside the stated range (below it).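

In this assay, hydrogen in place of methoxy on the aromatic carbon ortho to a large group and meta to a methoxy group gives an at least 50-fold lower number from compound 2 to compound 4 (1.69 log units; beyond the scatter). The same kind of change at the other place on the shared core gave an at least 1.0-fold higher number from compound 1 to compound 2 (0.03 log units; that floor lies within the scatter), so in these two cases the size of the step depends on the place of the change and not on the change alone. The new step is a floor and not a full size, because compound 2 stands at a limit: the limit of > 100000 nM in this assay, at which 2 of the 4 values shown sit.

The compounds shown leave open whether an ethoxy group, a hydroxyl group or an amine at this place would stay with compound 2 or move towards compound 4. Also open, as far as these compounds go, is what acetyl in place of trifluoromethyl does on the core of compound 4.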